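Ester chain lengthening in a small displacement series

The source may report more compounds than this note shows. Statements on the series, on what has been measured and on what is new or still open speak of the compounds shown alone.

Measured so far in an assay on CHO cells for displacement of a labelled ligand from adenosine receptor A1 (Homo sapiens), with a stated time of 60 min, tested at 10 uM; on this read-out lower numbers stand for less inhibition and higher numbers for more inhibition at the one concentration tested (going by the name of the read-out):
compound 1 `CC(=O)C1=C(C)NC(=O)NC1c1ccco1`: 30%
compound 2 `CCCC1=C(C(=O)OCC)C(c2ccco2)NC(=O)N1`: 50%
compound 3 `CCOC(=O)C1=C(C)NC(=S)NC1c1ccoc1`: 18%

Compound 3 stands lowest of the three numbers. Compound 1 is the nearest, sitting higher by more than the scatter, and compound 2 is furthest, higher again by more than the scatter. Among the measured compounds shown here, neither gap corresponds to a single structural change, so no step is available to anchor the next move.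

Compound 4 `CC1=C(C(=O)OC(C)C)C(c2ccoc2)NC(=S)N1` differs from compound 3 by methyl in place of hydrogen on a saturated chain carbon bound to an oxygen next to a carbonyl group and a saturated chain carbon. For the measured compounds named here, with no measured pair showing this change on its own, the expected movement in this assay is small, in neither direction beyond the scatter. Compound 4 is estimated at 20%, with a range from 5% to 38%. The expected step is a number 2 percentage points higher from compound 3 to compound 4 (within the scatter).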

Compound 4, a percentage reported as inhibition, at one concentration (the size of the read-out at that concentration, not a potency): 18%
Compound 4: middle estimate off by 2 percentage points, on the high side; measured number inside the range.
By their numbers in this assay, from the lowest: compounds 3 and 4 (each within the scatter of the next); then compound 1; then compound 2.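

In this assay, the ethoxy to isopropoxy change gives no change at the digits printed from compound 3 to compound 4 (within the scatter). Among the compounds shown here, this is the first single-place step, and it shows that methyl in place of hydrogen on this saturated chain carbon bound to an oxygen leaves the reading unchanged at this core. No measurement available here accounts for this flat result.

From the compounds shown here alone, whether a longer chain or a benzyl group at this place would shift the number stays open. Also open, going by these compounds, is whether the same change reads alike on the core of compound 2, which differs from compound 3 in more than one place.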